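Paw edema series: chloro for nitro on the aryl ring

A few compounds are considered here, and "the series" means these few. Any claim that something is new, unique, unknown or untested is made for them only; others in the source may bear on it.

Measured so far in a functional assay on the whole organism for inhibition, with Rattus norvegicus as the target, read by paw edema, with stated times of 30 min and 1 h, at a dose of 10 mg/kg by the oral route; a higher number here means more inhibition at the dose given (going by the name of the read-out), a lower number less inhibition:
compound 1 `O=C1N=C(C2C(=O)c3ccccc3C2=O)CC(c2ccccc2)N1`, 20%
compound 2 `COc1ccc(C2CC(C3C(=O)c4ccccc4C3=O)=NC(=O)N2)cc1`, 22%
compound 3 `O=C1N=C(C2C(=O)c3ccccc3C2=O)CC(c2ccc([N+](=O)[O-])cc2)N1`, 16%

Compound 3 gives the lowest of the three numbers, yet its gaps to the other two sit within the scatter: a number 4 percentage points lower from compound 1 to compound 3 (within the scatter) and a number 6 percentage points lower from compound 2 to compound 3 (within the scatter). Going by the values given here, the only other measured step, a number 2 percentage points higher from compound 1 to compound 2 (within the scatter), is within the scatter as well. Across all three compounds the read-out has stayed flat.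

Compound 4 `O=C1N=C(C2C(=O)c3ccccc3C2=O)CC(c2ccc(Cl)cc2)N1` has not yet been measured. It differs from compound 3 by chloro in place of nitro on an aromatic carbon. Among the compounds with values here, no measured step swaps the nitro for a chloro, so the nearest guides are the steps that touched this same aromatic carbon, a number 6 percentage points lower from compound 2 to compound 3 (within the scatter) and a number 4 percentage points lower from compound 1 to compound 3 (within the scatter), both within the scatter. No step beyond the scatter is therefore expected from compound 3 to compound 4 in this assay.

The estimate for compound 4 is 19%, with a range of 9% to 29%, meaning an expected step of a number 3 percentage points higher from compound 3 to compound 4 (within the scatter).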

Compound 4, a percentage reported as inhibition, in the whole organism at one dose (the size of the read-out at that dose, not a potency): 15%
Estimate against measurement, compound 4: 4 percentage points above, within the range that was stated.
By their numbers in this assay, from the lowest: compounds 4, 3, 1 and 2 (each within the scatter of the next).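

In this assay the change from 4-nitrophenyl to 4-chlorophenyl gives a number 1 percentage points lower from compound 3 to compound 4 (within the scatter) and so a halogen on this aromatic carbon reads the same as a nitro. Against the other two groups the chloro gives a number 7 percentage points lower from compound 2 to compound 4 (within the scatter) and a number 5 percentage points lower from compound 1 to compound 4 (within the scatter) and so the flat picture at this position now holds across hydrogen, methoxy, nitro and chloro, with no compound of the four standing apart. Nothing available explains why this position shows so little response to these changes.

Still open, from the compounds shown here alone, is whether a group of another kind on this carbon, such as an amine or a carboxylic acid, would move the read-out beyond the scatter. Also open, going by these compounds, is whether a change in the shared core, rather than on this aromatic ring, would do so.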